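This account rests on a few compounds, and the source may have more. Where it says the series, first, only, none or still open, it means among the compounds named here.

Compound 1 `CCCC(Oc1ccc2c(c1)c(SC(C)(C)C)c(CC(C)(C)C(=O)O)n2Cc1ccc(Cl)cc1)c1ccc2ccccc2n1` gives in a functional assay (blood) for inhibition, with Homo sapiens as the target (on this read-out lower numbers stand for stronger inhibition and higher numbers for weaker inhibition), only a limit of the assay, > 3000 nM. Going by the values given here, compound 2 `CC(C)(C)Sc1c(CC(C)(C)C(=O)O)n(Cc2ccc(Cl)cc2)c2ccc(OCc3ccc4cnccc4n3)cc12` gives 980 nM in this assay, the single real number among the values shown. Compound 3 `CC(C)(C)Sc1c(CC(C)(C)C(=O)O)n(Cc2ccc(Cl)cc2)c2ccc(OCc3ccncc3)cc12` has not been measured there yet. It differs from compound 2 by a group of 6 heavy atoms (5 carbon, 1 nitrogen; one six-membered aromatic ring with 1 hetero atom) in place of a group of 10 heavy atoms (8 carbon, 2 nitrogen; 2 six-membered aromatic rings with 1 hetero atom each), on a saturated chain carbon bound to an oxygen on an aromatic ring. Among the compounds with values here, since no measured step between compounds is available to set the size, the step is expected to run toward weaker inhibition, beyond the usual scatter, as a 2.6-fold higher number from compound 2 to compound 3 (0.41 log units; beyond the scatter). For compound 3 in this assay the estimate is 2500 nM, between 800 nM and 8000 nM.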

Compound 3, half-maximal inhibitory concentration: > 3000 nM
Compound 3 gave a limit, no number; the forecaster's own chance of this, stated with the estimate: 35%; middle value at least 1.2-fold (0.07 log units) away from the limit.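

In this assay, going by these compounds alone, this gives the first readable step at this position: putting pyridin-4-yl in place of the group with 2 six-membered aromatic rings, on a saturated chain carbon bound to an oxygen on an aromatic ring, gives an at least 3.0-fold higher number from compound 2 to compound 3 (0.48 log units; beyond the scatter). The single ring therefore does not keep the inhibition seen with compound 2. The value of compound 3 is a limit, so the step gives only a minimum size: the limit of > 3000 nM in this assay, at which 2 of the 3 values shown sit.

As far as these compounds go, how much inhibition is lost beyond that limit stays open. So does whether a phenyl group or a pyridine ring bearing an amine would behave like pyridin-4-yl at this position.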